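Shortening a Propyl Chain on a Shared Core

The source may hold more compounds than are shown below. What is called first, only, known or untested is meant among the compounds shown, and "the series" means these compounds.

Of the compounds shown here, three built on one shared core have been measured in a functional assay with Alpha-1A adrenergic receptor (Homo sapiens) as the target, read by calcium flux; a lower number here means a smaller maximal response, a higher number a larger maximal response. Compound 1 `Cc1nc(-c2ccccc2NCC2=NCCN2)n(C)n1` gives 98% in this assay. Compound 2 `Cn1cc(-c2ccccc2NCC2=NCCN2)cn1` gives 39% there. Compound 3 `CCCn1nccc1-c1ccccc1NCC1=NCCN1` gives 59%, which places it second highest of the three: its number lies beyond the scatter above that of compound 2 and beyond the scatter below that of compound 1. Compound 4 `CCn1nccc1-c1ccccc1NCC1=NCCN1` has not yet been measured in this assay. It differs from compound 3 in one place: hydrogen in place of methyl on a saturated chain carbon, two bonds along the chain from an aromatic nitrogen. Among the compounds with values here, no pair among the measured compounds differs by exactly this kind of change, so there is no measured step to lean on. The change takes away a single carbon from a short chain and leaves the rest of the molecule as it is, so the expected step of a number 1 percentage points higher from compound 3 to compound 4 (within the scatter) is modest, quite possibly none beyond the scatter. Compound 4 is accordingly estimated to reach 60% in this assay, within a range from 38% to 82%.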

Compound 4, largest response reached (reported as maximal response), in percent of the reference or control that the assay uses: 81%
The estimate for compound 4 lay 21 percentage points below the measured number; the range from low to high includes it.
By their numbers in this assay, from the lowest: compound 2; then compound 3; then compound 4; then compound 1.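

In this assay the change from propyl to ethyl, which removes one carbon and leaves the rest of the molecule untouched, brings a number 22 percentage points higher from compound 3 to compound 4 (beyond the scatter) and shows that the response is sensitive to the length of this chain. Within the data shown here, no two of the earlier compounds differed in one place alone, so this is the first step in the set that can be tied to a single change. Nothing available explains why one carbon makes this difference.

From the compounds shown here alone, a single step cannot establish a trend, so it remains open whether a methyl in place of the ethyl would raise the response further or a longer chain such as butyl would lower it again. Also open, going by these compounds, is how a chain ending in an amine or a hydroxyl group would behave at this place.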